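Urea and thiourea pair, trifluoromethoxy for trifluoromethyl

The source may report more compounds than this note shows. Statements on the series, on what has been measured and on what is new or still open speak of the compounds shown alone.

Measured compounds:
compound 1 `CN1c2ccc(NC(=O)Nc3ccc(C(F)(F)F)cc3)cc2C(C)(C)C(O)C1(C)C` gives 700 nM
compound 2 `CN1c2ccc(NC(=S)Nc3ccc(C(F)(F)F)cc3)cc2C(C)(C)C(O)C1(C)C` gives 2300 nM
compound 3 `CN1c2ccc(NC(=O)Nc3ccc(OC(F)(F)F)cc3)cc2C(C)(C)C(O)C1(C)C` gives 1100 nM

All three numbers come from an assay on isolated protein for binding affinity to stress-70 protein, mitochondrial (Homo sapiens); on this read-out higher numbers stand for weaker binding and lower numbers for tighter binding. The difference between the core of compound 1 and the core of compound 2 is not broken down here; compound 2 stands highest of the three, beyond the scatter from compound 3 and from compound 1. From compound 1 to compound 3 the change is trifluoromethoxy in place of trifluoromethyl on an aromatic carbon, and the step is a 1.6-fold higher number from compound 1 to compound 3 (0.20 log units; within the scatter). Compound 4 `CN1c2ccc(NC(=S)Nc3ccc(OC(F)(F)F)cc3)cc2C(C)(C)C(O)C1(C)C` is not yet measured in this assay. It differs from compound 2 by trifluoromethoxy in place of trifluoromethyl on an aromatic carbon, the same change at the same place. The step from compound 2 to compound 4 is expected to be a 1.6-fold higher number from compound 2 to compound 4 (0.21 log units; within the scatter), set beside a 1.6-fold higher number from compound 1 to compound 3 (0.20 log units; within the scatter), resting on that single earlier step and on the fact that compound 2 gives 2300 nM. Compound 4 is therefore estimated at 3700 nM, between 1800 nM and 7500 nM.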

Compound 4, dissociation constant: 2900 nM
Beside the measured number, compound 4's estimate is 1.3-fold (0.11 log units) above it, and the stated range covers the measured number.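

In this assay, trifluoromethoxy in place of trifluoromethyl on the core of compound 2 gives a 1.3-fold higher number from compound 2 to compound 4 (0.10 log units; within the scatter). The two steps show no difference between the cores: the same change on two cores in this assay, a 1.6-fold higher number (0.20 log units; within the scatter) from compound 1 to compound 3 and a 1.3-fold higher number (0.10 log units; within the scatter) from compound 2 to compound 4, 1.2-fold (0.10 log units) apart, within the scatter of two such steps This supports carrying the change between these two cores with little expected shift in the dissociation constant, but both steps lie within the scatter, so neither shows that the change itself alters binding, and two pairs say nothing about any further core.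

The compounds shown leave open how a nitrile or a carboxylic acid in the place of trifluoromethyl would read in this assay. Going by these compounds, all four compounds also keep the hydroxyl group of the shared core, so the effect of an amine there remains open.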